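Aniline replacement ahead of measurement

The source may report more compounds than this note shows. Statements on the series, on what has been measured and on what is new or still open speak of the compounds shown alone.

Measured so far:
compound 1 `CC(C)c1ccc(-c2nc(SCc3cn(CC(=O)NC(=O)Nc4ccccn4)nn3)nc(Nc3ccccc3Cl)c2C#N)cc1`, in a functional assay on ECa-109 cells (Homo sapiens) for inhibition, read by MTT assay, with a stated time of 72 h; a lower number here means a stronger inhibitor, a higher number a weaker inhibitor: 23400 nM
compound 2 `CC(C)c1ccc(-c2nc(SCc3cn(CC(=O)NC(=O)Nc4ccccn4)nn3)nc(Nc3ccccc3F)c2C#N)cc1`, in this assay: 15500 nM

Compound 1 holds the higher of the two numbers; its nearest neighbour is compound 2, and the step of a 1.5-fold lower number from compound 1 to compound 2 (0.18 log units; within the scatter) lies within the scatter. Compound 3 `COc1ccc(Nc2nc(SCc3cn(CC(=O)NC(=O)Nc4ccccn4)nn3)nc(-c3ccc(C(C)C)cc3)c2C#N)cc1` differs from compound 1 by 4-methoxyphenyl in place of 2-chlorophenyl on a nitrogen on an aromatic ring. Among the compounds with values here, no measured step covers this change; the single step known exchanges one halogen for another on the same nitrogen and is within the scatter. With no guide beyond that, no step beyond the scatter is expected: a 1.2-fold lower number from compound 1 to compound 3 (0.07 log units; within the scatter). Compound 3 is therefore estimated at 20000 nM, range 5000 nM to 80000 nM.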

Compound 3, half-maximal inhibitory concentration: 5420 nM
The estimate for compound 3 lay 3.7-fold (0.57 log units) above the measured number, within the range that was stated.
By their numbers in this assay, from the lowest: compound 3; then compounds 2 and 1 (each within the scatter of the next).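

In this assay the aryl group on this nitrogen does move the number: 4-methoxyphenyl brings a 4.3-fold lower number from compound 1 to compound 3 (0.64 log units; beyond the scatter) and a 2.9-fold lower number from compound 2 to compound 3 (0.46 log units; beyond the scatter) in the two comparisons, whereas exchanging one halogen for the other stayed within the scatter. No evidence on hand explains this gain. The change replaces the substituent and also alters where it stands on the phenyl ring, and the compounds shown do not separate these two changes. As far as these compounds go, how an unsubstituted phenyl, or a phenyl carrying an amine or a carboxylic acid, would read on this nitrogen remains open.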